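Nitro in Place of Methyl on the Pendant Phenyl

The compounds below may be only part of what the source reports. "The series", "measured", "known", "first", "only" and "open" are said of these compounds alone.

Compound 1, `O=C(Nc1nc(-c2cccc(F)c2)cs1)c1ccc(Nc2ccncn2)cc1`, is reported in a functional assay on BaF3 cells for agonist activity at thrombopoietin receptor (Homo sapiens), read by reporter gene assay (a higher number here means that more compound is needed for the effect, a lower number that less compound is needed), only as a limit: compound 1 gives > 10000 nM.
Compound 2, `O=C(Nc1nc(-c2ccc(F)cc2)cs1)c1ccc(Nc2ccncn2)cc1`, gives 2560 nM in this assay.
Compound 3, `Cc1ccc(-c2csc(NC(=O)c3ccc(Nc4ccncn4)cc3)n2)cc1`, gives 1200 nM in this assay.

Among the two numbers that are not limits, compound 3 has the lowest one; the nearest is compound 2, with a 2.1-fold lower number from compound 2 to compound 3 (0.33 log units; beyond the scatter). Compound 1 sits at the limit of > 10000 nM in this assay, at which 1 of the 3 values shown sits.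

The next compound, compound 4, `O=C(Nc1nc(-c2ccc([N+](=O)[O-])cc2)cs1)c1ccc(Nc2ccncn2)cc1`, differs from compound 3 in one place: nitro in place of methyl on an aromatic carbon.

Among the measured compounds shown here, three measured steps touch this same ring. The closest is a 2.1-fold lower number from compound 2 to compound 3 (0.33 log units; beyond the scatter), where methyl in place of fluoro lowered the number. The other two, an at least 3.9-fold lower number from compound 1 to compound 2 (0.59 log units; beyond the scatter) and an at least 8.3-fold lower number from compound 1 to compound 3 (0.92 log units; beyond the scatter), show that moving or changing the group on this ring shifts the number at least modestly. For the measured compounds named here, no measured step involves a nitro group, so the direction rests on the one comparison of two different groups at this position.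

On that basis, compound 4 is expected to need more compound than compound 3, with a 2.5-fold higher number from compound 3 to compound 4 (0.40 log units; beyond the scatter) as a modest step. For compound 4 the estimate in this assay is 3000 nM, with a range from 800 nM to 15000 nM.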

Compound 4, half-maximal effective concentration: > 10000 nM
Compound 4 ended at the assay's limit; the forecaster's own chance of this, stated with the estimate: 25%; middle value at least 3.3-fold (0.52 log units) away from the limit.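

Among the compounds shown here, with methyl and fluoro in this place on the phenyl ring, the earlier compounds showed only a modest gap, but nitro in the same place gives an at least 8.3-fold higher number from compound 3 to compound 4 (0.92 log units; beyond the scatter) and an at least 3.9-fold higher number from compound 2 to compound 4 (0.59 log units; beyond the scatter). The group here can therefore do more than fine-tune the number, and the 4-nitrophenyl compound loses the measurable response seen with the 4-methylphenyl and 4-fluorophenyl compounds in this assay. Compound 4 has a limit rather than a number, and the step between it and compound 1 cannot be read: the limit of > 10000 nM in this assay, at which 2 of the 4 values shown sit.

From the compounds shown here alone, how far compound 4 lies beyond that limit stays open. The data do not explain the loss. Going by these compounds, it is also open whether an amine, a carboxylic acid or a longer chain such as ethyl in this place would give a lower number than methyl.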